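Adding a second fluoro to compound 2

The source may report more compounds than this note shows. Statements on the series, on what has been measured and on what is new or still open speak of the compounds shown alone.

Compound 1 `O=[N+]([O-])c1cccc(CSc2nnc(-c3ccc4c(c3)OCCO4)n2-c2ccccc2)c1`: 45200 nM
Compound 2 `Fc1ccccc1CSc1nnc(-c2ccc3c(c2)OCCO3)n1-c1ccccc1`: 24300 nM

Among the measured compounds shown here, in a functional assay on HeLa cells (Homo sapiens) for antiproliferative activity, read by MTT assay, with a stated time of 24 h (a lower number here means a stronger inhibitor, a higher number a weaker inhibitor), compound 2 gives 24300 nM, and the only other measured number, that of compound 1, lies within the scatter of it. So compound 2 cannot yet be ranked.

The next compound, compound 3 `Fc1cccc(F)c1CSc1nnc(-c2ccc3c(c2)OCCO3)n1-c1ccccc1`, turns the 2-fluorobenzyl group into a 2,6-difluorobenzyl group: fluoro in place of hydrogen on an aromatic carbon. This puts fluoro in place of hydrogen on an aromatic carbon, ortho to a large group and meta to a fluoro group.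

For the measured compounds named here, only one measured step bears on this, a much larger swap on the same part of the molecule: a 1.9-fold lower number from compound 1 to compound 2 (0.27 log units; within the scatter). Even that swap left the number in this assay within the scatter, so no clear shift is expected here, in either direction. The expected change is a 1.0-fold higher number from compound 2 to compound 3 (0.01 log units; within the scatter). Compound 3 is expected at 25000 nM, with an estimated range of 13000 nM to 48000 nM.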

Compound 3, half-maximal inhibitory concentration: 35200 nM
For compound 3 the middle estimate is 1.4-fold (0.15 log units) below the measured one, and the stated range covers the measured number.
By their numbers in this assay, from the lowest: compounds 2, 3 and 1 (each within the scatter of the next).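

In this assay, the second fluoro gives a 1.4-fold higher number from compound 2 to compound 3 (0.16 log units; within the scatter), so on this evidence, fluoro in place of hydrogen at this place on the ring has no readable effect on the number. The wider swap gives a 1.3-fold lower number from compound 1 to compound 3 (0.11 log units; within the scatter), so the 2,6-difluorobenzyl and 3-nitrobenzyl groups cannot be told apart either, and all three compounds now lie within the scatter of one another. No measurement available here bears on why this is so.

On these data alone, what stays open is whether any group on this ring can move the number beyond the scatter, for instance a methoxy group or an amine in place of the fluoro. An unsubstituted benzyl group would also show whether the ring needs a fluoro or nitro group at all in this assay.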